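The source may report more compounds than this note shows. Statements on the series, on what has been measured and on what is new or still open speak of the compounds shown alone.

Compound 2 `N#Cc1ccc(NC(=O)c2ccc3cccnc3c2O)cc1` gives 180 nM in a functional assay on Jurkat cells (Homo sapiens) for cytotoxicity, read by luminescence and CellTiter-Glo, with a stated time of 3 days (on this read-out higher numbers stand for weaker inhibition and lower numbers for stronger inhibition), and stands lowest of the three numbers, though its nearest neighbour is within the scatter. Compound 1 `O=C(Nc1ccc(Cl)cc1)c1ccc2cccnc2c1O` gives 510 nM, and compound 3 `N#Cc1ccc(NC(=O)c2cc(Br)c3cccnc3c2O)cc1` gives 230 nM. The measured steps are a 2.8-fold lower number from compound 1 to compound 2 (0.45 log units; beyond the scatter) and a 1.3-fold higher number from compound 2 to compound 3 (0.11 log units; within the scatter). Compound 4 `N#Cc1ccc(NC(=O)c2ccc3cccnc3c2O)c(F)c1` differs from compound 2 by fluoro in place of hydrogen on an aromatic carbon. For the measured compounds named here, no measured step adds a fluoro; the only added halogen, from compound 2 to compound 3, sits on the shared core and gave a 1.3-fold higher number from compound 2 to compound 3 (0.11 log units; within the scatter), within the scatter. On that basis a step of a 1.1-fold higher number from compound 2 to compound 4 (0.05 log units; within the scatter) is expected, no more than the scatter. Compound 4 is therefore estimated at 200 nM in this assay, in the range 90 nM to 450 nM.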

Compound 4, half-maximal inhibitory concentration: 420 nM
For compound 4 the middle estimate is 2.1-fold (0.32 log units) below the measured one; the measured number falls inside the stated range.
By their numbers in this assay, from the lowest: compounds 2, 3, 4 and 1 (each within the scatter of the next, the first and the last beyond it).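

Fluoro in place of hydrogen, ortho to a large group and meta to a cyano group, gives a 2.3-fold higher number from compound 2 to compound 4 (0.37 log units; beyond the scatter) in this assay. A single added heavy atom at this place on the ring therefore moves the number beyond the scatter, unlike the added bromo on the shared core, which gave a 1.3-fold higher number from compound 2 to compound 3 (0.11 log units; within the scatter). No measured data on these compounds account for the fluoro step.

Still open, going by these compounds, is how a methoxy group or an amine would read at this place. Also open, on these data alone, is whether the fluoro step would hold with the chloro of compound 1 in place of the cyano group.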